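This account rests on a few compounds, and the source may have more. Where it says the series, first, only, none or still open, it means among the compounds named here.

Compound 1 `COc1ccc(-c2ccc(-c3ccc(-c4nc5cc(C)ccc5[nH]4)cc3)cc2)cc1OC`: 3510 nM
Compound 2 `COc1ccc(-c2ccc(-c3ccc(-c4nc5ccccc5[nH]4)cc3)cc2)cc1`: 2760 nM

Both numbers come from a functional assay on SiHa cells (Homo sapiens) for inhibition, read by sulforhodamine B assay (on this read-out lower numbers stand for stronger inhibition of growth and higher numbers for weaker inhibition of growth), and they lie within the usual scatter of repeated measurements of each other. Compound 2 therefore stands level with compound 1, and neither can be ranked ahead of the other.

Compound 3 `COc1ccc(-c2ccc(-c3ccc(-c4nc5ccccc5[nH]4)cc3)cc2)cc1OC` has not yet been measured. The change from compound 2 to compound 3 is methoxy in place of hydrogen on an aromatic carbon and it puts methoxy in place of hydrogen on an aromatic carbon, so that 4-methoxyphenyl becomes 3,4-dimethoxyphenyl.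

Among the measured compounds shown here, no two measured compounds differ in one place only, so the evidence for any forecast is thin. Still, compound 1 also carries a 3,4-dimethoxyphenyl group and gives 3510 nM in this assay on a scale where compound 2 gives 2760 nM and the two cannot be told apart. The expected step of a 1.1-fold higher number from compound 2 to compound 3 (0.04 log units; within the scatter) is therefore no larger than the scatter and has no clear direction. Compound 3 is estimated at 3000 nM in this growth test, with an expected range from 1300 nM to 7000 nM for its result.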

Compound 3, concentration for 50% growth inhibition: 6200 nM
Compound 3: the middle estimate sits 2.1-fold (0.32 log units) below what was measured; measured number inside the range.
By their numbers in this assay, from the lowest: compounds 2, 1 and 3 (each within the scatter of the next, the first and the last beyond it).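

In this assay, adding a methoxy group ortho to the existing methoxy group, which turns 4-methoxyphenyl into 3,4-dimethoxyphenyl, gives a modest but readable loss of growth inhibition (a 2.2-fold higher number from compound 2 to compound 3 (0.35 log units; beyond the scatter)), so this carbon of the ring is not indifferent to substitution. The other single change, hydrogen in place of methyl on an aromatic carbon, gives a step that cannot be told from repeat-measurement noise (a 1.8-fold higher number from compound 1 to compound 3 (0.25 log units; within the scatter)), so compound 1 and compound 3 cannot be ranked and that methyl shows no clear effect of its own. No measurement here bears on why the added methoxy goes with weaker growth inhibition.

Going by these compounds, it remains open whether the loss is specific to methoxy or would also appear with another group on the same carbon, such as hydroxy, fluorine, ethoxy or an amine. A single step also cannot show whether adding this methoxy would cost the same in a compound that keeps the methyl on the core, since the 4-methoxyphenyl partner of compound 1 is not among the compounds shown.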